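The source may report more compounds than this note shows. Statements on the series, on what has been measured and on what is new or still open speak of the compounds shown alone.

In a functional assay on LNCaP cells (Homo sapiens) for antiproliferative activity, read by MTT assay, with a stated time of 24 h (on this read-out lower numbers stand for stronger inhibition and higher numbers for weaker inhibition), compound 3 `COc1ccc(-c2noc(-c3ccc(F)cc3)n2)cc1OC1CCCC1` gives 87900 nM, the highest of the two numbers at hand; its nearest neighbour is compound 2 `COc1ccc(-c2noc(-c3ccc(Cl)cc3)n2)cc1OC1CCCC1`, which gives 20800 nM. Compound 1 `COc1ccc(-c2noc(-c3ccccc3)n2)cc1OC1CCCC1` returns only a limit of the assay, > 1000000 nM. Two measured steps reach compound 3, namely an at least 11-fold lower number from compound 1 to compound 3 (1.05 log units; beyond the scatter) and a 4.2-fold higher number from compound 2 to compound 3 (0.63 log units; beyond the scatter). Compound 4 `COc1ccc(-c2noc(-c3ccc(O)cc3)n2)cc1OC1CCCC1` differs from compound 3 by hydroxy in place of fluoro on an aromatic carbon. Among the measured compounds shown here, no measured step exchanges a halogen for a hydroxy group, so these steps bear on it only indirectly: the halogen on that ring carbon lowered the number, and its removal sent the number to the limit. A modest step upward is expected, a 1.7-fold higher number from compound 3 to compound 4 (0.23 log units; within the scatter). Compound 4 is estimated at 150000 nM, likely between 30000 nM and 900000 nM.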

Compound 4, half-maximal inhibitory concentration: 860 nM
Compound 4: middle estimate off by 170-fold (2.24 log units), on the high side; measured number outside the range, below it.
By their numbers in this assay, from the lowest: compound 4; then compound 2; then compound 3. At a limit, above all of these: compound 1.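

In this assay, the change from 4-fluorophenyl to 4-hydroxyphenyl gives a 100-fold lower number from compound 3 to compound 4 (2.01 log units; beyond the scatter), and the change from chloro gives a 24-fold lower number from compound 2 to compound 4 (1.38 log units; beyond the scatter). The earlier compounds shown here showed only that halogens on this carbon, para to a large group, differ from hydrogen and from each other; hydroxy now gives the lowest number of the series, so the lowest number here does not belong to a halogen. Against hydrogen the change gives an at least 1100-fold lower number from compound 1 to compound 4 (3.06 log units; beyond the scatter), a bound only, as compound 1 stands at a limit: the limit of > 1000000 nM in this assay, at which 1 of the 4 values shown sits.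

Going by these compounds, what a methoxy group, an amine or a carboxylic acid on this carbon would give remains open.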